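The source may hold more compounds than are shown below. What is called first, only, known or untested is meant among the compounds shown, and "the series" means these compounds.

Measured in a functional assay on MCF7 cells (Homo sapiens) for cytotoxicity, read by MTT assay, with a stated time of 72 h; on this read-out lower numbers stand for stronger inhibition and higher numbers for weaker inhibition:
- compound 1 `COc1cc(/C=C/C(=O)Nc2cc3c(Nc4ccc(F)c(Cl)c4)ncnc3cc2O[C@H]2CCOC2)cc(OC)c1OC`: 28400 nM
- compound 2 `COc1ccc(OC)c(/C=C/C(=O)Nc2cc3c(Nc4ccc(F)c(Cl)c4)ncnc3cc2O[C@H]2CCOC2)c1`: 36300 nM

Only these two compounds have been measured, and they stand level within the scatter. Compound 2, at 36300 nM, therefore has one close neighbour and no wider series around it. Compound 3 `O=C(/C=C/c1cc(Br)c(O)c(Br)c1)Nc1cc2c(Nc3ccc(F)c(Cl)c3)ncnc2cc1O[C@H]1CCOC1` differs from compound 2 in a single place: 3,5-dibromo-4-hydroxyphenyl in place of 2,5-dimethoxyphenyl on a double-bonded chain carbon bound to a double-bonded chain carbon. In words, 3,5-dibromo-4-hydroxyphenyl stands in place of 2,5-dimethoxyphenyl on a double-bonded chain carbon bound to a double-bonded chain carbon.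

Among the measured compounds shown here, one measured step bears on this change, a swap at the same place: a 1.3-fold higher number from compound 1 to compound 2 (0.11 log units; within the scatter). It shows that these two groups leave the number in this assay unmoved beyond the scatter. On these data alone, neither measured compound carries the 3,5-dibromo-4-hydroxyphenyl group, however, so this support is thin and the direction of any shift remains open. No clear change beyond the scatter is therefore expected, and the expected step is a 1.5-fold lower number from compound 2 to compound 3 (0.16 log units; within the scatter). The estimated value for compound 3 is 25000 nM, with an expected range of 8000 nM to 60000 nM.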

Compound 3, half-maximal inhibitory concentration: 30600 nM
Estimate against measurement, compound 3: 1.2-fold (0.09 log units) below, within the range that was stated.
By their numbers in this assay, from the lowest: compounds 1, 3 and 2 (each within the scatter of the next).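

The new group gives this position its first substituents other than methoxy, yet in this assay the 3,5-dibromo-4-hydroxyphenyl group gives a 1.2-fold lower number from compound 2 to compound 3 (0.07 log units; within the scatter), and in place of 3,4,5-trimethoxyphenyl it gives a 1.1-fold higher number from compound 1 to compound 3 (0.03 log units; within the scatter). Both steps lie within the scatter, so the three compounds stand level, and this holds for a group that brings bromine atoms and a hydrogen-bond donor in place of methoxy groups. These compounds offer no independent measurement that could account for this lack of movement.

The compounds shown leave open whether an amine or a carboxylic acid on this aromatic ring, or a saturated ring in its place, would shift the number in this assay beyond the scatter. They also leave open whether any change on the shared core, rather than on the group at this double-bonded chain carbon, would move the number at all.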